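This account rests on a few compounds, and the source may have more. Where it says the series, first, only, none or still open, it means among the compounds named here.

Measured so far:
- compound 1 `O=C1O[C@H]([C@@H](O)Cn2cc(CNS(=O)(=O)c3ccc(F)cc3)nn2)C(OCc2ccccc2)=C1OCc1ccccc1`: 22900 nM in a functional assay on HCT-116 cells (Homo sapiens) for antiproliferative activity, read by MTT assay, with a stated time of 72 h; a lower number here means a stronger inhibitor, a higher number a weaker inhibitor
- compound 2 `O=C1O[C@H]([C@@H](O)Cn2cc(C3CC3)nn2)C(OCc2ccccc2)=C1OCc1ccccc1`: 30400 nM in this assay

Compound 2 has the higher of the two numbers, but the gap to compound 1, a 1.3-fold higher number from compound 1 to compound 2 (0.12 log units; within the scatter), lies within the scatter, so no order can be read. Compound 3 `CCCCCc1ccc(-c2cn(C[C@H](O)[C@H]3OC(=O)C(OCc4ccccc4)=C3OCc3ccccc3)nn2)cc1` differs from compound 2 by 4-pentylphenyl in place of cyclopropyl on an aromatic carbon. For the measured compounds named here, the only measured step touches the same carbon and stayed within the scatter, so only a modest change is expected, with the larger group tilting the guess toward a somewhat lower number: a 2.0-fold lower number from compound 2 to compound 3 (0.31 log units; beyond the scatter). Compound 3 is estimated at 15000 nM, ranging from 5000 nM to 45000 nM.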

Compound 3, half-maximal inhibitory concentration: 13800 nM
Estimate against measurement, compound 3: 1.1-fold (0.04 log units) above; the range from low to high includes it.
By their numbers in this assay, from the lowest: compounds 3, 1 and 2 (each within the scatter of the next, the first and the last beyond it).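

For the compounds shown here, with 4-pentylphenyl on this aromatic carbon, the shared core gives the first step beyond the scatter in this assay (a 2.2-fold lower number from compound 2 to compound 3 (0.34 log units; beyond the scatter)). Against the (((4-fluorophenyl)sulfonyl)amino)methyl group, however, the same change stays within the scatter (a 1.7-fold lower number from compound 1 to compound 3 (0.22 log units; within the scatter)), so these three quite different groups leave the numbers close together, with only the 4-pentylphenyl and cyclopropyl pair clearly apart. From the compounds shown here alone, whether an amine or a carboxylic acid on this carbon would give a larger shift remains open. No measured evidence here explains the difference between these compounds.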